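The source may report more compounds than this note shows. Statements on the series, on what has been measured and on what is new or still open speak of the compounds shown alone.

Compound 3 `Cc1cc(NC(=O)C2CCOCC2)nn1Cc1cc(Cl)ccc1OCc1ccccc1` stands second highest of the three numbers in hand for an assay on CHO-K1 cells for displacement of a labelled ligand from prostaglandin E2 receptor EP1 subtype (Homo sapiens); a lower number here means a stronger inhibitor, a higher number a weaker inhibitor: compound 3 gives 63.1 nM, and its nearest neighbour is compound 2 `Cc1cc(C(=O)NCc2cccnc2)nn1Cc1cc(Cl)ccc1OCc1ccccc1`, which in this assay gives 50.1 nM; the gap a 1.3-fold higher number from compound 2 to compound 3 (0.10 log units; within the scatter) lies within the scatter. The furthest is compound 1 `Cc1cc(C(=O)Nc2cccc(F)c2)nn1Cc1cc(Cl)ccc1OCc1ccccc1`, which in this assay gives 200 nM, the step of a 3.2-fold lower number from compound 1 to compound 3 (0.50 log units; beyond the scatter) being beyond the scatter, as is a 4.0-fold lower number from compound 1 to compound 2 (0.60 log units; beyond the scatter).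

Compound 4 `Cc1cc(NC(=O)OCc2ccccn2)nn1Cc1cc(Cl)ccc1OCc1ccccc1` differs from compound 3 in one place: (pyridin-2-yl)methoxy in place of oxan-4-yl on a carbonyl carbon. Among the measured compounds shown here, no measured step makes this same change. For the measured compounds named here, the steps that bear on it are indirect: a pyridinylmethyl group on the amide-type nitrogen in compound 2 sits among the lower numbers, and the oxan-4-yl amide of compound 3 is within the scatter of it. A change of this size at the carbonyl carbon is therefore expected to move this assay little, and the estimated step of a 1.3-fold lower number from compound 3 to compound 4 (0.10 log units; within the scatter) is small. For compound 4 the estimate in this assay is 50 nM, with a range from 15 nM to 200 nM.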

Compound 4, half-maximal inhibitory concentration: 79.4 nM
Beside the measured number, compound 4's estimate is 1.6-fold (0.20 log units) below it; the measured number falls inside the stated range.
By their numbers in this assay, from the lowest: compounds 2, 3 and 4 (each within the scatter of the next); then compound 1.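

In this assay, the step of a 1.3-fold higher number from compound 3 to compound 4 (0.10 log units; within the scatter) lies within the scatter, which shows that this carbonyl carbon can carry either the non-aromatic oxan-4-yl ring or the aromatic (pyridin-2-yl)methoxy group without a measurable change. The (((pyridin-2-yl)methoxy)carbonyl)amino group also stays within the scatter of the ((pyridin-3-yl)methyl)carbamoyl group, with the step of a 1.6-fold higher number from compound 2 to compound 4 (0.20 log units; within the scatter), while the step of a 2.5-fold lower number from compound 1 to compound 4 (0.40 log units; beyond the scatter) is beyond the scatter, so compound 4 joins compound 2 and compound 3 in their separation from compound 1. No available evidence accounts for these results.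

Going by these compounds, what remains open is whether an amine or a longer chain on this carbonyl carbon would stay within the same scatter. On these data alone, it is also open whether phenylmethoxy would match (pyridin-2-yl)methoxy, which would show whether the pyridine nitrogen matters here.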